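The compounds below may be only part of what the source reports. "The series", "measured", "known", "first", "only" and "open" are said of these compounds alone.

Measured compounds:
- Compound 1 `COC1=C(C)C(=O)/C(=C(O)/C=C/c2cccc(OC)c2)C(=O)C1(C)C`: 4.5 ug/mL
- Compound 2 `COC1=C(C)C(=O)/C(=C(O)/C=C/c2ccccc2OC)C(=O)C1(C)C`: 6.6 ug/mL
- Compound 3 `CCc1ccc(/C=C/C(O)=C2/C(=O)C(C)=C(OC)C(C)(C)C2=O)cc1`: 12 ug/mL

In a functional assay on A-431 cells (Homo sapiens) for cytotoxicity (a higher number here means that more compound is needed for the effect, a lower number that less compound is needed), compound 3 gives 12 ug/mL, and the measured steps reaching it are a 2.7-fold higher number from compound 1 to compound 3 (0.43 log units; beyond the scatter) and a 1.8-fold higher number from compound 2 to compound 3 (0.26 log units; within the scatter).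

Compound 4 `C=Cc1ccccc1/C=C/C(O)=C1/C(=O)C(C)=C(OC)C(C)(C)C1=O` has 2-vinylphenyl in place of 4-ethylphenyl on a double-bonded chain carbon bound to a double-bonded chain carbon. Going by the values given here, no measured step makes this exact swap, so the guides are indirect. The closest is compound 2, whose group is also named at the 2 position and which gives 6.6 ug/mL. A small move towards a lower number is therefore expected. The estimated change is a 1.6-fold lower number from compound 3 to compound 4 (0.20 log units; within the scatter). For compound 4 the estimated value is 7.5 ug/mL, with an expected range of 3.5 ug/mL to 16 ug/mL.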

Compound 4, concentration for half-maximal effect: 2.6 ug/mL
Estimate against measurement, compound 4: 2.9-fold (0.46 log units) above, and the stated range ends above it.
By their numbers in this assay, from the lowest: compounds 4, 1, 2 and 3 (each within the scatter of the next, the first and the last beyond it).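

In this assay, 2-vinylphenyl in place of 4-ethylphenyl gives a 4.6-fold lower number from compound 3 to compound 4 (0.66 log units; beyond the scatter), so two carbon-only phenyl groups of equal atom count can still differ beyond the scatter at this place. Vinyl in place of methoxy on an aromatic carbon gives a 2.5-fold lower number from compound 2 to compound 4 (0.40 log units; beyond the scatter), showing that this change also matters when the group is otherwise unchanged. Against 3-methoxyphenyl, the result is a 1.7-fold lower number from compound 1 to compound 4 (0.24 log units; within the scatter), which stays within the scatter, so these two groups cannot be separated here. From the compounds shown here alone, whether a longer chain or an amine in place of vinyl would hold this level remains open. Nothing available explains why these steps occur.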